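Amide substituent swaps on a shared core

This account rests on a few compounds, and the source may have more. Where it says the series, first, only, none or still open, it means among the compounds named here.

Among the compounds with values here, compound 3 `COC(=O)/C=C/C(=O)N[C@@H](C)Cn1ccc(-c2ccc(C#N)c(Cl)c2)n1` stands second highest of the three numbers so far in a functional assay on LNCaP cells (Homo sapiens) for antiproliferative activity, read by CCK-8 assay, with a stated time of 6 days (a lower number here means a stronger inhibitor, a higher number a weaker inhibitor), where compound 3 gives 2460 nM. Its nearer neighbour is compound 2 `C[C@@H](Cn1ccc(-c2ccc(C#N)c(Cl)c2)n1)NC(=O)c1ccccc1F`, which in this assay gives 1810 nM, and its further one is compound 1 `CC(O)c1ccc(C(=O)N[C@@H](C)Cn2ccc(-c3ccc(C#N)c(Cl)c3)n2)cc1`, which in this assay gives 3690 nM. The steps of a 1.5-fold lower number from compound 1 to compound 3 (0.18 log units; within the scatter) and a 1.4-fold higher number from compound 2 to compound 3 (0.13 log units; within the scatter) both lie within the scatter, while a 2.0-fold lower number from compound 1 to compound 2 (0.31 log units; beyond the scatter) is a modest step beyond it. Compound 4 `C[C@@H](Cn1ccc(-c2ccc(C#N)c(Cl)c2)n1)NC(=O)C1CC(=O)C1` differs from compound 3 at the same carbonyl carbon: 3-oxocyclobutyl in place of 2-(methoxycarbonyl)ethenyl on a carbonyl carbon. All changes made at this position among the measured compounds moved the number only a little, so a further exchange there is expected to stay within the scatter, in no clear direction. The step expected is a 1.0-fold higher number from compound 3 to compound 4 (0.01 log units; within the scatter). Compound 4 is therefore estimated at 2500 nM in this assay, with a range from 900 nM to 7000 nM.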

Compound 4, half-maximal inhibitory concentration: 3040 nM
The estimate for compound 4 lay 1.2-fold (0.08 log units) below the measured number; low and high end bracket the measured number.
By their numbers in this assay, from the lowest: compounds 2, 3, 4 and 1 (each within the scatter of the next, the first and the last beyond it).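

In this assay, the 3-oxocyclobutyl group on the carbonyl carbon gives a 1.2-fold higher number from compound 3 to compound 4 (0.09 log units; within the scatter) and a 1.7-fold higher number from compound 2 to compound 4 (0.23 log units; within the scatter) as well as a 1.2-fold lower number from compound 1 to compound 4 (0.08 log units; within the scatter) and so falls within the scatter of all three earlier groups. A non-aromatic four-membered ring of carbon only thus joins the 2-(methoxycarbonyl)ethenyl, 2-fluorophenyl and 4-(1-hydroxyethyl)phenyl groups in one narrow band, and compound 4 does not add a second pair beyond the scatter to that of compound 1 and compound 2. No evidence is available on why this exchange moved the number so little.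

The compounds shown leave open whether an amine or a carboxylic acid on this carbonyl carbon, or a longer chain, would take the number outside this band. They also leave open whether the same narrow band would hold with any other part of the shared core changed.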